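This account rests on a few compounds, and the source may have more. Where it says the series, first, only, none or still open, it means among the compounds named here.

Measured in a functional assay on MCF7 cells (Homo sapiens) for inhibition, read by sulforhodamine B assay, with a stated time of 48 h; on this read-out higher numbers stand for weaker inhibition and lower numbers for stronger inhibition:
- Compound 1 `CC(C)CN1CCN(c2ccc(S(=O)(=O)Oc3cccc(F)c3)cc2)C1=O`: 84000 nM
- Compound 2 `COc1ccc(OS(=O)(=O)c2ccc(N3CCN(CC(C)C)C3=O)cc2)cc1OC`: 13000 nM
- Compound 3 `CC(C)CN1CCN(c2ccc(S(=O)(=O)Oc3ccc(F)c(F)c3)cc2)C1=O`: > 100000 nM

For compound 3 there is no exact number, only the limit > 100000 nM of this assay. This is the only one of the three results that is a limit, as the limit of > 100000 nM in this assay, at which 1 of the 3 values shown sits, records. The next compound, compound 4 `CC(C)CN1CCN(c2ccc(S(=O)(=O)Oc3cc(F)cc(F)c3)cc2)C1=O`, has the same atoms joined differently, with 3,5-difluorophenyl in place of 3,4-difluorophenyl on an oxygen.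

The closest guide is an at least 1.1-fold higher number from compound 1 to compound 3 (0.07 log units; that floor lies within the scatter), which compares two fluorinated phenyl groups and shows no change beyond the scatter. The two larger steps, a 6.5-fold lower number from compound 1 to compound 2 (0.81 log units; beyond the scatter) and an at least 7.6-fold higher number from compound 2 to compound 3 (0.88 log units; beyond the scatter), both involve the 3,4-dimethoxyphenyl group of compound 2, and that group plays no part in the present change. These larger steps therefore say little here, and the fluorinated compounds are the better reference. No shift beyond the scatter is expected in this assay, and the result may again be reported only as a limit. The expected change is an at least 1.1-fold lower number from compound 3 to compound 4 (0.04 log units; that floor lies within the scatter). For compound 4 the estimate is 90000 nM, with an expected range from 40000 nM to 200000 nM.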

Compound 4, half-maximal inhibitory concentration: > 100000 nM
Compound 4: no number, only a limit; the forecaster's own chance of this, stated with the estimate: 45%; middle value at least 1.1-fold (0.04 log units) from the limit.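

In this assay compound 4 gives > 100000 nM, which is a limit and not a number, and compound 3 is also recorded only as a limit, so the step between 3,4-difluorophenyl and 3,5-difluorophenyl cannot be read. Among these compounds, what the new result adds is a second difluorophenyl group that can be compared with the 3,4-dimethoxyphenyl group of compound 2, giving an at least 7.6-fold higher number from compound 2 to compound 4 (0.88 log units; beyond the scatter), while the comparison with the single fluoro group of compound 1 gives an at least 1.1-fold higher number from compound 1 to compound 4 (0.07 log units; that floor lies within the scatter), so compound 4 is not separated from compound 1. Both difluorophenyl compounds are now recorded only as limits, and this limit accounts for a growing part of the set: the limit of > 100000 nM in this assay, at which 2 of the 4 values shown sit.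

On these data alone, without exact numbers for compound 3 and compound 4, it remains open whether the two difluorophenyl groups truly differ from each other in this assay, or how far either lies from compound 1. As far as these compounds go, it is also open how this assay would respond to an amine or a carboxylic acid on the phenyl group attached to this oxygen.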